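This account rests on a few compounds, and the source may have more. Where it says the series, first, only, none or still open, it means among the compounds named here.

Measured so far:
Compound 1 `CC1=C(/C=C/C(=O)/C=C/c2ccc(Cl)cc2)C(C)(C)CCC1` gives 10200 nM in a functional assay on MCF7 cells (Homo sapiens) for cytotoxicity, read by sulforhodamine B assay, with a stated time of 48 h; a higher number here means a weaker inhibitor, a lower number a stronger inhibitor.
Compound 2 `CC1=C(/C=C/C(=O)/C=C/c2ccc(Br)cc2)C(C)(C)CCC1` gives 20100 nM in this assay.

Compound 2 stands at the higher of the two numbers, with compound 1 its nearest neighbour by a 2.0-fold higher number from compound 1 to compound 2 (0.29 log units; within the scatter). Compound 3 `CC1=C(/C=C/C(=O)/C=C/c2ccc(F)cc2)C(C)(C)CCC1` carries fluoro in place of bromo on an aromatic carbon. Going by the values given here, the one measured step that bears on a halogen swap at this position is a 2.0-fold higher number from compound 1 to compound 2 (0.29 log units; within the scatter), which stayed within the scatter, so no step beyond the scatter is expected here either. Compound 3 is therefore estimated to reach about 15000 nM in this assay, between 5000 nM and 45000 nM, an expected step of a 1.3-fold lower number from compound 2 to compound 3 (0.13 log units; within the scatter).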

Compound 3, half-maximal inhibitory concentration: 6200 nM
Compound 3: the middle estimate sits 2.4-fold (0.38 log units) above what was measured; the range from low to high includes it.
By their numbers in this assay, from the lowest: compounds 3, 1 and 2 (each within the scatter of the next, the first and the last beyond it).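

In this assay, going by these compounds alone, a halogen swap at this position gives a step beyond the scatter for the first time: a 3.2-fold lower number from compound 2 to compound 3 (0.51 log units; beyond the scatter), a modest change with fluoro in place of bromo. Fluoro in place of chloro stays within the scatter, at a 1.6-fold lower number from compound 1 to compound 3 (0.22 log units; within the scatter), so compound 1 cannot be separated from either of the other two. Nothing available here explains the step. The three compounds differ only in their halogen, so they leave open how an amine, a methoxy group or a carboxylic acid at this position would compare.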